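Oxime acid series: aryl arm in place of branched alkyl

This account rests on a few compounds, and the source may have more. Where it says the series, first, only, none or still open, it means among the compounds named here.

Compound 3 `CCCCC(CCCC)C(O/N=C(\C)C(=O)O)c1ccc(OCc2ccc3ccccc3n2)cc1` gives 14 nM in a functional assay for inhibition of Polyunsaturated fatty acid 5-lipoxygenase (Homo sapiens); a higher number here means a weaker inhibitor, a lower number a stronger inhibitor. Among the measured compounds it sits second highest: compound 2 `CCCCC(CCCC)C(O/N=C/C(=O)O)c1ccc(OCc2ccc3ccccc3n2)cc1`, at 10 nM, lies within the scatter of it, while compound 1 `O=C(O)C1CCC(=NOC(c2ccc(OCc3ccc4ccccc4n3)cc2)C2CCCCC2)CC1`, at 67 nM, lies beyond the scatter on the weaker side. Compound 4 `C/C(=N\OC(CCCc1ccc(F)cc1)c1ccc(OCc2ccc3ccccc3n2)cc1)C(=O)O` is not yet measured; it differs from compound 3 by 3-(4-fluorophenyl)propyl in place of 1-butylpentyl on a saturated chain carbon bound to an aromatic carbon and an oxygen on an unsaturated carbon. Within the data shown here, the only single-place step recorded, a 1.4-fold higher number from compound 2 to compound 3 (0.15 log units; within the scatter), concerns a different place and leaves the 1-butylpentyl group unchanged, and compound 1 differs from compound 3 in more than one place. Among the measured compounds shown here, no measured step bears on this exchange, so the expected step is one of no more than the scatter, a 1.4-fold higher number from compound 3 to compound 4 (0.15 log units; within the scatter), with a wide band. Compound 4 is estimated at 20 nM, between 6 nM and 70 nM.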

Compound 4, half-maximal inhibitory concentration: 9 nM
Beside the measured number, compound 4's estimate is 2.2-fold (0.35 log units) above it, within the range that was stated.
By their numbers in this assay, from the lowest: compounds 4, 2 and 3 (each within the scatter of the next); then compound 1.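

At this position, on a saturated chain carbon bound to an aromatic carbon and an oxygen on an unsaturated carbon, the arm need not be branched alkyl: in this assay, 3-(4-fluorophenyl)propyl in place of 1-butylpentyl gives a 1.6-fold lower number from compound 3 to compound 4 (0.19 log units; within the scatter) and so stays within the scatter. A six-membered aromatic ring of carbon only is therefore accepted in this arm with no loss beyond the scatter. Nothing available explains this result.

On these data alone, it remains open how an unsubstituted phenyl in place of 4-fluorophenyl would read. A longer chain, or an amine at the end of this arm, is also an open question.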